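Swapping 4-bromophenyl for 3-chlorophenyl at an assay limit

The compounds below may be only part of what the source reports. "The series", "measured", "known", "first", "only" and "open" are said of these compounds alone.

Compound 1 (`COc1ccc(/C=C/C(=O)/C=C/c2cc3ccccc3nc2Oc2ccc(Br)cc2)cc1OC`) was tested in a functional assay on PC-3 cells (Homo sapiens) for cytotoxicity, read by MTT assay, with a stated time of 48 h; a higher number here means a weaker inhibitor, a lower number a stronger inhibitor. There compound 1 gives > 10000 nM and this is a limit, not a number. Compound 2 (`COc1cc(OC)c(/C=C/C(=O)/C=C/c2cc3ccccc3nc2Oc2ccc(Br)cc2)c(OC)c1`) gives > 10000 nM in the same test and this too is a limit. Compound 1 therefore stands at the limit of > 10000 nM in this assay, at which 2 of the 2 values shown sit, and has no exact potency to start from.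

Compound 3 (`COc1ccc(/C=C/C(=O)/C=C/c2cc3ccccc3nc2Oc2cccc(Cl)c2)cc1OC`) keeps the core of compound 1 and has 3-chlorophenyl in place of 4-bromophenyl on an oxygen on an aromatic ring. For the measured compounds named here, the only measured step, a step that the two limits leave unreadable from compound 1 to compound 2, lies at a different place in the molecule, and its size cannot be read. It therefore offers no size to carry over to this change, and no direction can be predicted in this assay. The estimated step is a step that the limit leaves unreadable from compound 1 to compound 3 and nothing beyond the usual scatter is expected. For compound 3 the expected value is 12000 nM with an estimated range from 3000 nM to 30000 nM and a limit instead of an exact number is the likeliest outcome.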

Compound 3, half-maximal inhibitory concentration: > 10000 nM
Compound 3 was reported as a limit; the forecaster's own chance of this, stated with the estimate: 65%; the middle value is on the limit's open side.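

In this assay, compound 1 and compound 3 are each reported only as a limit, so no step can be read for 3-chlorophenyl in place of 4-bromophenyl: the limit of > 10000 nM in this assay, at which 3 of the 3 values shown sit.

The compounds shown leave open what exact potency compound 1, compound 2 and compound 3 have, and whether either change alters it at all.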